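Replacing fluoro with cyano in compound 3

The compounds below may be only part of what the source reports. "The series", "measured", "known", "first", "only" and "open" are said of these compounds alone.

In a functional assay on HeLa cells (Homo sapiens) for cytotoxicity, read by MTT assay, with a stated time of 24 h (on this read-out higher numbers stand for weaker inhibition and lower numbers for stronger inhibition), compound 1 (`COc1ccc(/C=C2\CN(C)C/C(=C\c3ccccc3F)C2=O)cc1`) gives 23500 nM and compound 2 (`COc1ccc(/C=C2\CN(C)C/C(=C\c3ccccc3F)C2=O)cc1OC`) gives 14400 nM. Compound 3 (`COc1cc(/C=C2\CN(C)C/C(=C\c3ccc(F)cc3)C2=O)cc(OC)c1`) gives 10200 nM as its value, which is lower than compound 1 beyond the scatter and level with compound 2 within it. Compound 4 (`COc1cc(/C=C2\CN(C)C/C(=C\c3ccc(C#N)cc3)C2=O)cc(OC)c1`) has cyano in place of fluoro on an aromatic carbon of compound 3 (cyano in place of fluoro on an aromatic carbon). Among the measured compounds shown here, the one measured step (a 1.6-fold lower number from compound 1 to compound 2 (0.21 log units; within the scatter)) comes from methoxy in place of hydrogen, a different change, and no measured pair makes this swap. No step beyond the scatter is therefore expected in this assay and the estimated step is only a 1.1-fold lower number from compound 3 to compound 4 (0.05 log units; within the scatter) in size. Compound 4 is expected near 9000 nM (estimated range 3500 nM to 22000 nM).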

Compound 4, half-maximal inhibitory concentration: 3420 nM
The estimate for compound 4 lay 2.6-fold (0.42 log units) above the measured number; measured number below the stated range.
By their numbers in this assay, from the lowest: compound 4; then compounds 3, 2 and 1 (each within the scatter of the next, the first and the last beyond it).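

In this assay, cyano in place of fluoro gives a 3.0-fold lower number from compound 3 to compound 4 (0.47 log units; beyond the scatter), the only step shown that lies beyond the scatter. The group at this place on the ring can therefore shift the number, even though the swap adds only one heavy atom and one hydrogen-bond acceptor. Nothing measured here gives a reason for this step. From the compounds shown here alone, it remains open whether an amine or a carboxylic acid at the same place would lower the number further. Going by these compounds, whether the swap would act alike on the other aromatic ring also remains open.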